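The source may hold more compounds than are shown below. What is called first, only, known or untested is meant among the compounds shown, and "the series" means these compounds.

Going by the values given here, compound 2 `O=C1N=C(C2C(=O)c3ccccc3C2=O)CC(c2ccc([N+](=O)[O-])cc2)N1` is the lower of the two compounds so far tested in a functional assay on the whole organism for inhibition, with Rattus norvegicus as the target, read by paw edema, with stated times of 30 min and 4 h, at a dose of 10 mg/kg by the oral route (on this read-out higher numbers stand for more inhibition at the one dose given (going by the name of the read-out) and lower numbers for less inhibition), where compound 2 gives 18%. Among the compounds with values here, its only neighbour in the set is compound 1 `O=C1N=C(C2C(=O)c3ccccc3C2=O)CC(c2ccccc2[N+](=O)[O-])N1`, which in this assay gives 32%; the one measured step, a number 14 percentage points lower from compound 1 to compound 2 (beyond the scatter), moves the aryl substituent rather than exchanging it. Compound 3 `CN(C)c1ccc(C2CC(C3C(=O)c4ccccc4C3=O)=NC(=O)N2)cc1` differs from compound 2 by dimethylamino in place of nitro on an aromatic carbon. Within the data shown here, no measured step exchanges the group on the aryl ring, so the step from compound 1 to compound 2 does not bear on this change directly, and the data give no basis for expecting a shift in either direction beyond the scatter in this assay. Compound 3 is therefore expected to give roughly 22% in this assay, within a wide range of 5% to 45%, corresponding to an expected step of a number 4 percentage points higher from compound 2 to compound 3 (within the scatter) with considerable uncertainty.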

Compound 3, a percentage reported as inhibition, in the whole organism at one dose (the size of the read-out at that dose, not a potency): 16%
For compound 3 the middle estimate is 6 percentage points above the measured one; measured number inside the range.
By their numbers in this assay, from the lowest: compounds 3 and 2 (each within the scatter of the next); then compound 1.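

At the aromatic carbon para to a large group, in this assay, dimethylamino in place of nitro gives a number 2 percentage points lower from compound 2 to compound 3 (within the scatter), so this read-out does not separate the two groups at this place, although nitro carries a double bond outside aromatic rings and dimethylamino does not. With a number 16 percentage points lower from compound 1 to compound 3 (beyond the scatter), a second 4-substituted phenyl now stands apart from the 2-nitrophenyl of compound 1, so the gap first seen in a number 14 percentage points lower from compound 1 to compound 2 (beyond the scatter) is not confined to the nitro group at that place. No measurement at hand gives a reason for either step.

The compounds shown leave open whether a plain phenyl, or a phenyl bearing a carboxylic acid or a primary amine at this place, would read any differently. They also leave open whether the higher number of compound 1 would hold with another group in place of its nitro.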